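Changing the Benzyl Group on a Shared Core

The compounds below may be only part of what the source reports. "The series", "measured", "known", "first", "only" and "open" are said of these compounds alone.

In a functional assay on HepG2 cells (Homo sapiens) for antiproliferative activity, read by MTT assay, with a stated time of 48 h (on this read-out higher numbers stand for weaker inhibition and lower numbers for stronger inhibition), compound 1 `COc1ccc(-c2ccc3c(c2)C(=O)C(=O)N3Cc2ccc(Cl)c(Cl)c2)cc1` gives 990 nM, compound 2 `COc1ccc(-c2ccc3c(c2)C(=O)C(=O)N3Cc2ccccc2Cl)cc1` gives 600 nM and compound 3 `COc1ccc(-c2ccc3c(c2)C(=O)C(=O)N3Cc2ccc(Br)cc2)cc1` gives 700 nM. Compound 3 thus stands among three values that all lie within the usual scatter of one another. Compound 4 `COc1ccc(-c2ccc3c(c2)C(=O)C(=O)N3Cc2ccccc2OC)cc1` keeps the shared core and differs from compound 3 in one place: 2-methoxyphenyl in place of 4-bromophenyl on a saturated chain carbon bound to an amide-type nitrogen in a ring. Three measured steps change this same group: a 1.7-fold lower number from compound 1 to compound 2 (0.22 log units; within the scatter), a 1.4-fold lower number from compound 1 to compound 3 (0.15 log units; within the scatter) and a 1.2-fold higher number from compound 2 to compound 3 (0.07 log units; within the scatter). None of them exceeds the scatter, so no step beyond the scatter is expected in this assay. The 2-methoxyphenyl group itself remains unmeasured here, which calls for a wide range. The expected step is no change at the digits printed from compound 3 to compound 4 (within the scatter). For compound 4 the estimated value is 700 nM, with an expected range from 300 nM to 1600 nM.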

Compound 4, half-maximal inhibitory concentration: 130 nM
Compound 4: middle estimate off by 5.4-fold (0.73 log units), on the high side, outside the stated range (below it).
By their numbers in this assay, from the lowest: compound 4; then compounds 2, 3 and 1 (each within the scatter of the next).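

In this assay, among these compounds, the group on this saturated chain carbon does matter: there is a 5.4-fold lower number from compound 3 to compound 4 (0.73 log units; beyond the scatter) and a 4.6-fold lower number from compound 2 to compound 4 (0.66 log units; beyond the scatter) as well as a 7.6-fold lower number from compound 1 to compound 4 (0.88 log units; beyond the scatter) in this series, the first steps here beyond the scatter. The second of these is only methoxy in place of chloro on an aromatic carbon, so that single swap is enough to carry the change. No measurement at hand explains why this group gives the lower number.

As far as these compounds go, whether an ethoxy or a hydroxy group in place of methoxy would keep this low number stays open. So does the effect of an amine on the same ring.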